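The compounds below may be only part of what the source reports. "The series", "measured", "known", "first", "only" and "open" are said of these compounds alone.

Measured so far:
compound 1, `COc1cc2oc(-c3cccc(NC(=O)c4ccc(Cl)cc4)c3)cc(=O)c2c(OC)c1OC`, 51.1%
compound 2, `COc1cc2oc(-c3cccc(NC(=O)c4ccc(Br)cc4)c3)cc(=O)c2c(OC)c1OC`, 63.6%

Of the compounds shown here, two sharing one core have been tested in a functional assay on ACHN cells (Homo sapiens) for inhibition, read by sulforhodamine B assay, tested at 10 uM; a lower number here means less inhibition, a higher number more inhibition at the concentration tested (going by the name of the read-out). Compound 1 gives 51.1%, and compound 2 gives 63.6%. Compound 2 stands highest of the two, with compound 1 the nearest number, lying a number 12.5 percentage points higher from compound 1 to compound 2 (beyond the scatter).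

Compound 3, `COc1cc2oc(-c3cccc(C(=O)Nc4ccc(C)cc4)c3)cc(=O)c2c(OC)c1OC`, has not been measured. It differs from compound 2 by (4-methylphenyl)carbamoyl in place of ((4-bromophenyl)carbonyl)amino on an aromatic carbon. Within the data shown here, no measured step covers this change: the one step available, a number 12.5 percentage points higher from compound 1 to compound 2 (beyond the scatter), swaps one halogen for another at a single aromatic carbon and leaves the amide untouched, whereas compound 3 turns the amide around and replaces the bromo with a methyl. With nothing closer to rest on, the expectation for compound 3 is a number near the middle of the two known values, with wide uncertainty in either direction. The estimate for compound 3 in this assay is 50%, between 25% and 75%, which means a step of a number 13.6 percentage points lower from compound 2 to compound 3 (beyond the scatter) is expected.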

Compound 3, a percentage reported as inhibition, at one concentration (the size of the read-out at that concentration, not a potency): 55.7%
Compound 3: the middle estimate sits 5.7 percentage points below what was measured; the range from low to high includes it.
By their numbers in this assay, from the lowest: compounds 1, 3 and 2 (each within the scatter of the next, the first and the last beyond it).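

In this assay, (4-methylphenyl)carbamoyl in place of ((4-bromophenyl)carbonyl)amino gives a small step (a number 7.9 percentage points lower from compound 2 to compound 3 (within the scatter)), and in place of ((4-chlorophenyl)carbonyl)amino it gives another (a number 4.6 percentage points higher from compound 1 to compound 3 (within the scatter)). This place, on an aromatic carbon meta to a large group, therefore accepts a turned amide carrying methyl instead of a halogen, with compound 3 not separable from either halogen compound, even though those two stand apart from each other.

From the compounds shown here alone, compound 3 changes the amide direction and the ring substituent at once, so the share of each remains open. Also open, going by these compounds, is how an amine or a carboxylic acid on that outer ring would read in this assay. No measurement shown here offers an explanation for these numbers.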